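Halogen exchange on the benzoyl ring: cytotoxicity notes

The source may report more compounds than this note shows. Statements on the series, on what has been measured and on what is new or still open speak of the compounds shown alone.

Of the compounds shown here, two have been tested so far. Compound 1 `Cn1cnc(C(=O)NNC(=O)COc2c(F)cc(C(=O)c3ccc(F)cc3)cc2Cl)c1` carries a fluoro group on the benzoyl ring; in an ADME assay on NIH3T3 cells (Mus musculus) for cytotoxicity, read by trypan blue exclusion, with a stated time of 48 h (on this read-out lower numbers stand for stronger inhibition and higher numbers for weaker inhibition), compound 1 gives 94200 nM. Compound 2 `Cn1cnc(C(=O)NNC(=O)COc2ccc(C(=O)c3ccccc3)cc2)c1`, which lacks the halogens on both aromatic rings, gives in this assay a value of 98800 nM. Going by the values given here, the two numbers lie within the scatter of each other, so compound 1 and compound 2 cannot be told apart on these data, and no step between measured compounds can be computed.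

Compound 3 `Cn1cnc(C(=O)NNC(=O)COc2c(F)cc(C(=O)c3ccc(Cl)cc3)cc2Cl)c1` is not yet measured. Relative to compound 1 the difference is chloro in place of fluoro on an aromatic carbon. With only one halogen exchanged on an aromatic carbon, and with compound 1 and compound 2 giving nearly the same number despite a larger difference between them, no step beyond the scatter is expected in this assay, in either direction.

For compound 3 the expected value in this assay is therefore 90000 nM, with a range from 45000 nM to 180000 nM, which means an expected step of a 1.0-fold lower number from compound 1 to compound 3 (0.02 log units; within the scatter).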

Compound 3, half-maximal inhibitory concentration: 90900 nM
The estimate for compound 3 lay 1.0-fold (0.00 log units) below the measured number; the measured number falls inside the stated range.
By their numbers in this assay, from the lowest: compounds 3, 1 and 2 (each within the scatter of the next).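

In this assay the exchange of 4-fluorophenyl for 4-chlorophenyl gives a 1.0-fold lower number from compound 1 to compound 3 (0.02 log units; within the scatter) and so leaves the two halogens indistinguishable at this place, on an aromatic carbon para to a large group. Going by these compounds alone, this is the first comparison in which the compounds differ in one place only, so the absence of a step beyond the scatter can now be tied to a single named exchange rather than to several differences at once. The data offer no measurement that would explain why fluoro and chloro read alike here.

From the compounds shown here alone, both groups compared at this place are single halogen atoms, so it remains open whether an amine, a carboxylic acid, a methoxy group or a longer chain on the same carbon would also stay within the scatter in this assay or move the number beyond it. Also open, going by these compounds, is whether the same exchange of fluoro for chloro would read alike on the other aromatic ring of the shared core, where the halogens of compound 1 and compound 3 stay unchanged.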